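Benzothiazole in place of the thienylphenyl arm

This account rests on a few compounds, and the source may have more. Where it says the series, first, only, none or still open, it means among the compounds named here.

Compound 1 `CN1CCN(c2ccc3nc(-c4ccc(-c5ccccc5)s4)c(-c4ccncc4)n3n2)CC1`: > 10000 nM
Compound 2 `CN1CCN(c2ccc3nc(-c4cccc(-c5cccs5)c4)c(-c4ccncc4)n3n2)CC1`: 270 nM

In an assay on Sf9 cells for inhibition of receptor-interacting serine/threonine-protein kinase 3 (Homo sapiens), read by luminescence and 33P incorporation, with a stated time of 30 min, in the presence of a further agent that is not named here (on this read-out lower numbers stand for stronger inhibition and higher numbers for weaker inhibition), compound 1 gives only a limit, > 10000 nM. Compound 2 holds the only number shown, 270 nM, and the step of an at least 37-fold lower number from compound 1 to compound 2 (1.56 log units; beyond the scatter) rests on that limit (the limit of > 10000 nM in this assay, at which 1 of the 2 values shown sits). Compound 3 `CN1CCN(c2ccc3nc(-c4ccc5ncsc5c4)c(-c4ccncc4)n3n2)CC1` carries 1,3-benzothiazol-6-yl in place of 3-(thiophen-2-yl)phenyl on an aromatic carbon. Among the compounds with values here, only the step from compound 1 to compound 2 bears on it, and it was large, so a move away from the thienylphenyl arm is expected to cost potency; the step from compound 2 to compound 3 is estimated at a 5.6-fold higher number from compound 2 to compound 3 (0.74 log units; beyond the scatter). Compound 3 is therefore expected near 1500 nM, within 300 nM to 8000 nM.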

Compound 3, half-maximal inhibitory concentration: > 10000 nM
Compound 3: no number, only a limit; the forecaster's own chance of this, stated with the estimate: 20%; at least 6.6-fold (0.82 log units) between middle value and limit.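

Replacing 3-(thiophen-2-yl)phenyl with the fused 1,3-benzothiazol-6-yl on this aromatic carbon gives an at least 37-fold higher number from compound 2 to compound 3 (1.56 log units; beyond the scatter), so the loss seen with 5-phenylthiophen-2-yl is not confined to that arm. Of the three arms shown, only the one in compound 2 gives a number in this assay, and the value for compound 3 is only a limit: the limit of > 10000 nM in this assay, at which 2 of the 3 values shown sit. The step between compound 1 and compound 3 cannot be read, as both values are limits. From the compounds shown here alone, it remains open whether a plain phenyl, or a phenyl carrying an amine at the place of the thiophene, would keep a measurable value.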